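Amide variation on the biphenyl side chain

This account rests on a few compounds, and the source may have more. Where it says the series, first, only, none or still open, it means among the compounds named here.

Measured so far in this series:
compound 1 `CC(=O)NCc1ccccc1-c1ccc(COC2CC[C@H](N3CCCCCC3)[C@H]2OC/C=C\CCC(=O)O)cc1`: 25.1 nM
compound 2 `O=C(O)CC/C=C\CO[C@H]1[C@@H](OCc2ccc(-c3ccccc3CO)cc2)CC[C@@H]1N1CCCCCC1`: 1.59 nM
compound 3 `O=C(O)CC/C=C\CO[C@@H]1[C@@H](OCc2ccc(-c3ccccc3)cc2)CC[C@@H]1N1CCCCC1`: 100 nM

In a functional assay on blood for antagonist activity at thromboxane A2 receptor (Homo sapiens) (a lower number here means tighter binding, a higher number weaker binding), compound 1 gives 25.1 nM, the second highest of the three numbers. Compound 3 gives 100 nM, a higher number beyond the scatter. Compound 2 gives 1.59 nM, the lowest of the three and well beyond the scatter from compound 1. Compound 4 `NC(=O)Cc1ccccc1-c1ccc(COC2CC[C@H](N3CCCCCC3)[C@H]2OC/C=C\CCC(=O)O)cc1` has not been measured in this assay. It differs from compound 1 in one place: carbamoyl in place of acetamido on a saturated chain carbon bound to an aromatic carbon. Within the data shown here, no measured pair shows the same change, so the expected step from compound 1 to compound 4 is small, a 1.3-fold lower number from compound 1 to compound 4 (0.10 log units; within the scatter), likely not beyond the scatter in either direction. Compound 4 is therefore expected to give about 20 nM, within 6 nM to 80 nM.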

Compound 4, dissociation constant: 7.94 nM
Beside the measured number, compound 4's estimate is 2.5-fold (0.40 log units) above it; the measured number falls inside the stated range.
By their numbers in this assay, from the lowest: compound 2; then compound 4; then compound 1; then compound 3.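

In this assay, the place on the saturated chain carbon bound to an aromatic carbon responds to a small change: carbamoyl in place of acetamido gives a 3.2-fold lower number from compound 1 to compound 4 (0.50 log units; beyond the scatter), a modest step beyond the scatter. This is the only single-place step shown, and it appears although the two groups have the same counts of hydrogen-bond donors and acceptors. Nothing available accounts for the step.

Still open, going by these compounds, is whether a methylcarbamoyl group, a carboxylic acid or a primary amine at this place would continue this step or reverse it. On these data alone, the effect of a longer chain carrying the carbamoyl group also remains open.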